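Removing a methyl from an oxygen: will the cells tolerate less?

This account rests on a few compounds, and the source may have more. Where it says the series, first, only, none or still open, it means among the compounds named here.

Of the compounds shown here, two have so far been tested in a functional assay on UACC-62 cells (Homo sapiens) for inhibition, read by sulforhodamine B assay, with a stated time of 48 h; a lower number here means that less compound is tolerated, a higher number that more compound is tolerated. Compound 1, with the structure `O=C(Nc1cccc(-n2cc(-c3ccncc3)c(-c3ccc(Cl)c(O)c3)n2)c1)Nc1ccc(Cl)c(Cl)c1`, gives a value of 29200 nM. Compound 2, with the structure `COc1cc(-c2nn(-c3cccc(NC(=O)Nc4cccc(C(F)(F)F)c4)c3)cc2-c2ccncc2)ccc1Cl`, gives 3480 nM in this assay. Of these two numbers, compound 2 stands at the lower end; compound 1 sits well above it, beyond the usual scatter. The two compounds differ in more than one place, so no single change can be credited for the gap.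

Compound 3, with the structure `O=C(Nc1cccc(-n2cc(-c3ccncc3)c(-c3ccc(Cl)c(O)c3)n2)c1)Nc1cccc(C(F)(F)F)c1`, is the next to be measured in this assay. It keeps everything of compound 2 except one small change: hydrogen in place of methyl on an oxygen on an aromatic ring, that is, methoxy becomes hydroxy. Compound 1 carries the same hydroxy group, but also a different urea end, so it cannot show the effect of this change alone. A modest upward step is expected from compound 2 to compound 3, of about a 1.7-fold higher number from compound 2 to compound 3 (0.24 log units; within the scatter). Compound 3 is thus estimated at 6000 nM in this assay, within a range from 2000 nM to 18000 nM.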

Compound 3, concentration lethal to 50% of the cells: 21900 nM
For compound 3 the middle estimate is 3.7-fold (0.56 log units) below the measured one, outside the stated range (above it).
By their numbers in this assay, from the lowest: compound 2; then compounds 3 and 1 (each within the scatter of the next).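

In this assay, hydrogen in place of methyl on this oxygen, methoxy to hydroxy, gives a 6.3-fold higher number from compound 2 to compound 3 (0.80 log units; beyond the scatter), so the cells tolerate more of the compound, not less, and this single change accounts for a gap beyond the scatter. With the hydroxy group kept, 3-(trifluoromethyl)phenyl in place of 3,4-dichlorophenyl on the amide-type nitrogen gives a 1.3-fold lower number from compound 1 to compound 3 (0.12 log units; within the scatter), so this change at the urea end has no readable effect here. Nothing available explains why the methyl matters so much to the cells.

The methoxy to hydroxy step is shown with only the 3-(trifluoromethyl)phenyl urea end, so whether it holds with the 3,4-dichlorophenyl end stays open. From the compounds shown here alone, how the cells would respond to a longer chain on this oxygen, such as ethoxy, or to an amine in place of the hydroxy also remains open.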